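The compounds below may be only part of what the source reports. "The series", "measured", "known", "first", "only" and "open" are said of these compounds alone.

Measured compounds in a functional assay on HCT-116 cells (Homo sapiens) for antiproliferative activity, read by MTT assay, with a stated time of 48 h; a lower number here means a stronger inhibitor, a higher number a weaker inhibitor:
Compound 1 `O=C(Nc1cc(Sc2ncn[nH]2)c(O)c2ccccc12)c1cccc([N+](=O)[O-])c1` gives 70200 nM.
Compound 2 `COc1ccc(/C=C/C(=O)Nc2cc(Sc3ncn[nH]3)c(O)c3ccccc23)cc1OC` gives only a limit of the assay, > 100000 nM.
Compound 3 `O=C(/C=C/c1ccccc1)Nc1cc(Sc2ncn[nH]2)c(O)c2ccccc12` also gives only a limit, > 100000 nM.

Compound 3 thus stands at the limit (the limit of > 100000 nM in this assay, at which 2 of the 3 values shown sit), without a number of its own, and the step that the two limits leave unreadable from compound 2 to compound 3 cannot be read. Going by the values given here, the only step touching a number is an at least 1.4-fold higher number from compound 1 to compound 3 (0.15 log units; that floor lies within the scatter), which moved the value from a measured number to the limit when the group on the carbonyl carbon changed. Compound 4 `COc1cccc(C(=O)Nc2cc(Sc3ncn[nH]3)c(O)c3ccccc23)c1` differs from compound 3 in that (3-methoxyphenyl in place of 2-phenylethenyl on a carbonyl carbon). This puts an aromatic ring on the carbonyl carbon again, as in compound 1 with its 70200 nM. Compound 4 is therefore expected near 90000 nM, within 35000 nM to 250000 nM. The expected step is an at least 1.1-fold lower number from compound 3 to compound 4 (0.04 log units; that floor lies within the scatter), a return from the limit toward a measurable number, though a limit again remains likely.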

Compound 4, half-maximal inhibitory concentration: > 100000 nM
Compound 4 was reported as a limit (the forecaster's own chance of this, stated with the estimate: 50%); middle value at least 1.1-fold (0.04 log units) away from the limit.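

Replacing 2-phenylethenyl with 3-methoxyphenyl on the carbonyl carbon puts an aromatic ring there again, yet in this assay compound 4 gives only a limit, not a number: the limit of > 100000 nM in this assay, at which 3 of the 4 values shown sit. Methoxy in place of nitro on an aromatic carbon gives an at least 1.4-fold higher number from compound 1 to compound 4 (0.15 log units; that floor lies within the scatter), leaving compound 1 the only one of the four with a measured number. The steps between the limits cannot be read.

On these data alone, it remains open whether an amine or a carboxylic acid on that aromatic carbon would give a measured number. As far as these compounds go, how far compound 2, compound 3 and compound 4 lie beyond the limit also stays unknown.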